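A few compounds are considered here, and "the series" means these few. Any claim that something is new, unique, unknown or untested is made for them only; others in the source may bear on it.

Compound 1, `COc1ccc(NC(=O)Nc2nn(C)c3cc(Oc4ccnc5cc(OC)c(OC)cc45)ccc23)cc1`: > 1000 nM (a limit of the assay)
Compound 2, `COc1ccc(Nc2nn(C)c3cc(Oc4ccnc5cc(OC)c(OC)cc45)ccc23)cc1`: > 1000 nM (a limit of the assay)
Compound 3, `COc1cc2nccc(Oc3ccc4c(NC(=O)Nc5ccc(C)cc5)nn(C)c4c3)c2cc1OC`: > 1000 nM (a limit of the assay)

All three measurements come from a functional assay on HUVEC cells (Homo sapiens) for inhibition, with stated times of 2 h and 72 h; on this read-out higher numbers stand for weaker inhibition and lower numbers for stronger inhibition. Compound 3 sits at the limit of this assay, with > 1000 nM, so no number is known for it. The same holds for every value shown: the limit of > 1000 nM in this assay, at which 3 of the 3 values shown sit. For that reason none of the steps between the measured compounds can be read in size. The step that the two limits leave unreadable from compound 1 to compound 2, the step that the two limits leave unreadable from compound 1 to compound 3 and the step that the two limits leave unreadable from compound 2 to compound 3 all lie between two limits.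

The unmeasured compound 4, `COc1cc2nccc(Oc3ccc4c(Nc5ccccc5)nn(C)c4c3)c2cc1OC`, differs from compound 3 in one place: phenyl in place of (4-methylphenyl)carbamoyl on a nitrogen on an aromatic ring. The closest measured comparison is the exchange of a carbamoyl group for an aryl group on the same nitrogen, seen in the step that the two limits leave unreadable from compound 2 to compound 3, which gives no readable size. Compound 2 already carries an anilino group and still sits at the limit, so the expectation for compound 4 is no readable step: a step that the limit leaves unreadable from compound 3 to compound 4 is expected, most likely leaving compound 4 at the limit as well. The estimate for compound 4 in this assay is therefore 3000 nM, with a range from 800 nM to 20000 nM, and a high chance that only a limit is reported.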

Compound 4, half-maximal inhibitory concentration: > 1000 nM
Compound 4: a limit, no number; the forecaster's own chance of this, stated with the estimate: 85%; the middle value does not contradict the limit.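

Compound 4 gives > 1000 nM, which is a limit of the assay and not a number. No step from compound 1, compound 2 or compound 3 to compound 4 can therefore be read in size: the limit of > 1000 nM in this assay, at which 4 of the 4 values shown sit.

The compounds shown leave open how strongly any of them inhibits, and whether any single exchange changes that.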